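Replacing naphthalen-1-yl with 4-methylphenyl in compound 2

The compounds below may be only part of what the source reports. "The series", "measured", "known", "first", "only" and "open" are said of these compounds alone.

In a functional assay on PC-9 cells (Homo sapiens) for inhibition, read by MTT assay, with a stated time of 72 h (on this read-out higher numbers stand for weaker inhibition and lower numbers for stronger inhibition), compound 1 `Cc1cc(Nc2cc(-c3ccccc3)[nH]n2)n2nc(SCc3ccc(F)cc3)nc2n1` gives 8110 nM and compound 2 `Cc1cc(Nc2ccn(Cc3cccc4ccccc34)n2)n2nc(SCc3ccc(Br)cc3)nc2n1` gives 5660 nM. These two numbers lie within the usual scatter of each other, so compound 2 cannot be told apart from compound 1 on this evidence.

The next compound, compound 3 `Cc1ccc(Cn2ccc(Nc3cc(C)nc4nc(SCc5ccc(Br)cc5)nn34)n2)cc1`, shares the core of compound 2 and differs from it in one place: 4-methylphenyl stands in place of naphthalen-1-yl on a saturated chain carbon bound to an aromatic nitrogen (4-methylphenyl in place of naphthalen-1-yl on a saturated chain carbon bound to an aromatic nitrogen). The same change can also be read as (naphthalen-1-yl)methyl to 4-methylbenzyl.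

Among the compounds with values here, no pair of measured compounds differing in one place exists yet, so nothing shows directly how large such a step can be in this assay. The best starting point is therefore compound 2 at 5660 nM, and no step beyond the scatter is expected, in either direction. The expected change is a 1.1-fold higher number from compound 2 to compound 3 (0.06 log units; within the scatter). For compound 3 the estimated value is 6500 nM, with an expected range from 2800 nM to 15000 nM.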

Compound 3, half-maximal inhibitory concentration: > 50000 nM
Compound 3: no number, only a limit (the forecaster's own chance of this, stated with the estimate: 5%); at least 7.6-fold (0.88 log units) between middle value and limit.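

Within the data shown here, this is the first pair of compounds that differ in one place, and it shows that the group on a saturated chain carbon bound to an aromatic nitrogen matters in this assay: putting 4-methylphenyl in place of naphthalen-1-yl gives an at least 8.8-fold higher number from compound 2 to compound 3 (0.94 log units; beyond the scatter). Both groups consist of carbon only and carry no hydrogen-bond donors or acceptors, so even a swap between two such aromatic groups can produce a step beyond the scatter. For compound 3, the value of > 50000 nM is a limit of the assay and not a number, so the step has a known minimum but no known full size: the limit of > 50000 nM in this assay, at which 1 of the 3 values shown sits.

This single pair cannot separate the loss of one six-membered aromatic ring from the arrival of the methyl group, since the two come together in the same change. Going by these compounds, a plain phenyl or a 4-chlorophenyl on the same chain carbon could help tell these apart, and it remains open whether any group at this position gives a lower number than compound 2.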